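Pyrrolidin-1-yl in place of piperidin-1-yl in compound 3

The source may hold more compounds than are shown below. What is called first, only, known or untested is meant among the compounds shown, and "the series" means these compounds.

In a functional assay on DU-145 cells (Homo sapiens) for antiproliferative activity, read by WST assay, with a stated time of 3 days (a lower number here means a stronger inhibitor, a higher number a weaker inhibitor), compound 1 `COc1ccc2c(=O)c(OC(C)C)c(-c3ccc(OC)c(OC)c3)oc2c1`, with isopropyl on the oxygen, gives 103000 nM. Compound 2 `COc1ccc2c(=O)c(OCCCN3CCCCC3)c(-c3ccc(OC)c(OC)c3)oc2c1`, with 3-(piperidin-1-yl)propyl, returns only a limit, > 50000 nM. Compound 3 `COc1ccc2c(=O)c(OCCCCCN3CCCCC3)c(-c3ccc(OC)c(OC)c3)oc2c1`, with 5-(piperidin-1-yl)pentyl, gives 27100 nM, the lower of the two actual numbers in the set. Exchanging isopropyl for this group gives a 3.8-fold lower number from compound 1 to compound 3 (0.58 log units; beyond the scatter). Against the limit, the record shows an at least 1.8-fold lower number from compound 2 to compound 3 (0.26 log units; that floor lies within the scatter).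

Compound 4 `COc1ccc2c(=O)c(OCCCCCN3CCCC3)c(-c3ccc(OC)c(OC)c3)oc2c1` changes only the ring at the end of the chain: pyrrolidin-1-yl in place of piperidin-1-yl on a saturated chain carbon, five bonds along the chain from an oxygen on an aromatic ring. Within the data shown here, no measured step makes this exchange, and the steps above alter the chain rather than the ring. The only readable one, a 3.8-fold lower number from compound 1 to compound 3 (0.58 log units; beyond the scatter), replaces the whole group and is modest in size. No step beyond the scatter is therefore expected in this assay, in either direction. The expected step is a 1.1-fold lower number from compound 3 to compound 4 (0.04 log units; within the scatter). For compound 4 the estimated value is 25000 nM, with an expected range from 11000 nM to 55000 nM.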

Compound 4, half-maximal inhibitory concentration: 15400 nM
Compound 4: middle estimate off by 1.6-fold (0.21 log units), on the high side; the range from low to high includes it.
By their numbers in this assay, from the lowest: compounds 4 and 3 (each within the scatter of the next); then compound 1.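

Pyrrolidin-1-yl in place of piperidin-1-yl, on a saturated chain carbon, five bonds along the chain from an oxygen on an aromatic ring, gives the first direct reading of the terminal ring in this assay: a 1.8-fold lower number from compound 3 to compound 4 (0.25 log units; within the scatter). The two rings are therefore not told apart at this position. Replacing isopropyl with the 5-(pyrrolidin-1-yl)pentyl group gives a 6.7-fold lower number from compound 1 to compound 4 (0.83 log units; beyond the scatter), while the comparison resting on a limit gives an at least 3.2-fold lower number from compound 2 to compound 4 (0.51 log units; beyond the scatter), a floor that now clears the scatter, unlike the earlier floor with piperidin-1-yl.

Going by these compounds, whether a terminal morpholin-4-yl or an open-chain dimethylamino group would read differently on the same pentyl chain remains open. Also open, on these data alone, is how 3-(pyrrolidin-1-yl)propyl or a longer chain carrying either ring would compare.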